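The compounds below may be only part of what the source reports. "The series", "measured", "known", "first", "only" and "open" are said of these compounds alone.

Measured in a functional assay on MCF7 cells (Homo sapiens) for inhibition (on this read-out lower numbers stand for stronger inhibition and higher numbers for weaker inhibition), are three compounds:

Compound 1 `CCCCCC[C@@]1(C)SC(=O)C=C1OCC(=O)OCC` gives 14.2 ug/mL
Compound 2 `CCCCCCCC[C@@]1(C)SC(=O)C=C1OCC(=O)OCC` gives 10.8 ug/mL
Compound 3 `CCCCCC[C@@]1(C)SC(=O)C=C1OCC(=O)NCC(=O)OC` gives 9.8 ug/mL

Compound 2 stands within the scatter of both other compounds, so the three values form one group with no order among them. Compound 4 `CCCCCCCC[C@@]1(C)SC(=O)C=C1OC(=O)OCC` carries ethoxycarbonyl in place of (ethoxycarbonyl)methyl on an oxygen on an unsaturated carbon. Among the measured compounds shown here, no measured step makes this exact change. The closest one is ((methoxycarbonyl)methyl)amino in place of ethoxy on a carbonyl carbon (a 1.4-fold lower number from compound 1 to compound 3 (0.16 log units; within the scatter)). Ethyl in place of hydrogen on a saturated chain carbon also bears on the series, as a measure of how little the values have moved so far (a 1.3-fold lower number from compound 1 to compound 2 (0.12 log units; within the scatter)). Both steps stay within the scatter, though neither is a direct precedent, so no step beyond the scatter is expected in either direction. The expected change is a 1.1-fold higher number from compound 2 to compound 4 (0.05 log units; within the scatter) and it carries no firm direction. For compound 4 the estimate is 12 ug/mL with an expected range from 6 ug/mL to 25 ug/mL in this assay as the read-out.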

Compound 4, half-maximal inhibitory concentration: 14.5 ug/mL
The estimate for compound 4 lay 1.2-fold (0.08 log units) below the measured number; measured number inside the range.
By their numbers in this assay, from the lowest: compounds 3, 2, 1 and 4 (each within the scatter of the next).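

In this assay, the step from (ethoxycarbonyl)methyl to ethoxycarbonyl on the oxygen on an unsaturated carbon gives a 1.3-fold higher number from compound 2 to compound 4 (0.13 log units; within the scatter) and is the first step shown that alters the group attached directly to this oxygen. The earlier steps shown here changed only the saturated chain or the far end of the ester side chain, whereas this one shortens (ethoxycarbonyl)methoxy to (ethoxycarbonyl)oxy and, like them, does not take the number beyond the scatter. No evidence is available that would explain this result or bear on it.

Since every step shown stays within the scatter, it remains open whether any change at this oxygen can move the number beyond it. Whether an amine or a carboxylic acid in this place would do so is also unresolved.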